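Trimming a benzyl to a methyl on a selenium-bearing chain

A few compounds are considered here, and "the series" means these few. Any claim that something is new, unique, unknown or untested is made for them only; others in the source may bear on it.

Compound 1 `O=C(/N=C(/NC(=O)c1ccno1)[Se]Cc1ccccc1)c1ccno1` and compound 2 `C[Se]/C(=N\C(=O)c1ccno1)NC(=O)c1ccno1` share one core and differ only by hydrogen in place of phenyl on a saturated chain carbon bound to a selenium atom. In a functional assay on K562 cells (Homo sapiens) for cytotoxicity, read by MTT assay, with a stated time of 72 h (on this read-out lower numbers stand for higher toxicity in this test and higher numbers for lower toxicity in this test), compound 1 gives 94700 nM. For compound 2 this assay reports only a limit, > 100000 nM. The step of an at least 1.0-fold higher number from compound 1 to compound 2 (0.02 log units; that floor lies within the scatter) is therefore a floor, set because the limit of > 100000 nM in this assay, at which 1 of the 3 values shown sits, caps what can be seen.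

Compound 3 `O=C(/N=C(/NC(=O)c1csc([N+](=O)[O-])c1)[Se]Cc1ccccc1)c1csc([N+](=O)[O-])c1` carries a different core; the difference between the two cores is not broken down here. In this assay compound 3 gives 88200 nM. Compound 4 `C[Se]/C(=N\C(=O)c1csc([N+](=O)[O-])c1)NC(=O)c1csc([N+](=O)[O-])c1` differs from compound 3 by hydrogen in place of phenyl on a saturated chain carbon bound to a selenium atom, the same change as before. Since the floor an at least 1.0-fold higher number from compound 1 to compound 2 (0.02 log units; that floor lies within the scatter) lies within the scatter, the step of a 1.2-fold higher number from compound 3 to compound 4 (0.10 log units; within the scatter) is expected to be small too. Compound 4 is estimated at 110000 nM, between 60000 nM and 250000 nM.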

Compound 4, concentration lethal to 50% of the cells: > 100000 nM
Compound 4: only a limit was reported; the forecaster's own chance of this, stated with the estimate: 60%; the middle value is on the limit's open side.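

In this assay, trimming benzyl to methyl on the second core gives an at least 1.1-fold higher number from compound 3 to compound 4 (0.05 log units; that floor lies within the scatter). Compound 4 is reported only as a limit, so this step is a floor and not a measured size. The change therefore cannot be said to carry over from one core to the other with the same size, nor to behave differently on each: the same change on two cores in this assay, an at least 1.0-fold higher number (0.02 log units; that floor lies within the scatter) from compound 1 to compound 2 and an at least 1.1-fold higher number (0.05 log units; that floor lies within the scatter) from compound 3 to compound 4; the limit leaves it open whether they differ

Going by these compounds, how a longer chain, or a chain ending in an amine, would read in place of the benzyl stays open, as does the true size of both steps. Any such comparison remains narrow while values sit at this limit: the limit of > 100000 nM in this assay, at which 2 of the 4 values shown sit.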